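The source may report more compounds than this note shows. Statements on the series, on what has been measured and on what is new or still open speak of the compounds shown alone.

In a functional assay on cells (Neutrophil, Homo sapiens) for inhibition, with a stated time of 10 min (a higher number here means a weaker inhibitor, a lower number a stronger inhibitor), compound 2 `NC(=O)c1cnn2c1N(C(=O)Nc1cccc(F)c1)C(c1ccccc1)C2` gives 3.9 nM, the lowest of the numbers shown. Compound 3 `NC(=O)c1cnn2c1N(C(=O)Nc1cccc3ccccc13)C(c1ccccc1)C2` gives 110 nM, and the step of a 28-fold higher number from compound 2 to compound 3 (1.45 log units; beyond the scatter) is large. In this assay compound 1 `NC(=O)c1cnn2c1N(C(=O)Nc1ccccc1F)C(c1ccccc1)C2` gives > 1000 nM, which is a limit of the assay and not a number. The steps of an at least 250-fold lower number from compound 1 to compound 2 (2.40 log units; beyond the scatter) and an at least 9.0-fold lower number from compound 1 to compound 3 (0.95 log units; beyond the scatter) show how strongly the aryl group on the amide-type nitrogen matters. Compound 4 `O=C(c1cnn2c1N(C(=O)Nc1cccc(F)c1)C(c1ccccc1)C2)N1CCCCC1` keeps that aryl group and changes the other end instead: piperidin-1-yl in place of amino on a carbonyl carbon. For the measured compounds named here, none of the measured steps touches this carbonyl, so they give no direct guide, and the expectation rests on compound 2 alone. Compound 4 is therefore expected to give about 30 nM in this assay, between 4 nM and 400 nM, an estimated step of a 7.7-fold higher number from compound 2 to compound 4 (0.89 log units; beyond the scatter) whose direction is uncertain.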

Compound 4, half-maximal inhibitory concentration: 5.5 nM
Compound 4: middle estimate off by 5.5-fold (0.74 log units), on the high side, within the range that was stated.
By their numbers in this assay, from the lowest: compounds 2 and 4 (each within the scatter of the next); then compound 3. At a limit, above all of these: compound 1.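

In this assay, putting piperidin-1-yl in place of amino on the carbonyl carbon gives a 1.4-fold higher number from compound 2 to compound 4 (0.15 log units; within the scatter). So this position, unlike the aryl group on the amide-type nitrogen, accepts a far larger group with a ring, and the hydrogen-bond donor of the amino group can go without a change beyond the scatter. Nothing shown here offers an explanation for this result.

Still open, going by these compounds, is whether a morpholine ring, a longer chain on the amide nitrogen or a carboxylic acid would fare the same at this carbonyl. Also open, on these data alone, is whether piperidin-1-yl would behave alike alongside the naphthalen-1-yl group of compound 3.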